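A few compounds are considered here, and "the series" means these few. Any claim that something is new, unique, unknown or untested is made for them only; others in the source may bear on it.

Two members of the series have numbers in a functional assay on the whole organism (strain albino) for inhibition, with Rattus norvegicus as the target, read by paw edema, with stated times of 1 h and 3 h, at a dose of 20 mmol/kg by the intraperitoneal route; a higher number here means a stronger effect of the compound at the dose given, a lower number a weaker effect. Compound 1 `COc1ccc(N/C=N/C2=C(C#N)C3C(N4CCCC4)CCCCN3C(=O)N2c2ccccc2)cc1` gives 50.2% there, the lower of the two values; compound 2 `N#Cc1c2n(c(=O)n(-c3ccccc3)c1=N)CCCCC2N1CCCC1` gives 93.4%, a reading beyond the scatter above it. Compound 3 `N#CC1=C(/N=C/c2ccc([N+](=O)[O-])cc2)N(c2ccccc2)C(=O)N2CCCCC(N3CCCC3)C12` has not yet been measured in this assay. It differs from compound 1 in one place: 4-nitrophenyl in place of (4-methoxyphenyl)amino on a carbon with a double bond to nitrogen. Within the data shown here, no measured pair shows the effect of such a change. The step is therefore expected to be small, in either direction or none beyond the scatter, namely a number 4.8 percentage points higher from compound 1 to compound 3 (within the scatter). Compound 3 is accordingly estimated at 55%, within a range from 30% to 80%.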

Compound 3, a percentage reported as inhibition, in the whole organism at one dose (the size of the read-out at that dose, not a potency): 91.7%
Compound 3: the middle estimate sits 36.7 percentage points below what was measured; measured number above the stated range.
By their numbers in this assay, from the lowest: compound 1; then compounds 3 and 2 (each within the scatter of the next).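

In this assay the group on a carbon with a double bond to nitrogen is not a silent position: 4-nitrophenyl in place of (4-methoxyphenyl)amino gives a large step (a number 41.5 percentage points higher from compound 1 to compound 3 (beyond the scatter)). The change removes the hydrogen-bond donor of the leaving group and adds a hydrogen-bond acceptor, but these counts are not tied to the step by any measurement. No available evidence explains the step.

Open, going by these compounds, is whether the step follows the nitro group, the loss of the amino link or both. An unsubstituted phenyl or a 4-methoxyphenyl without the amino link at this place would help separate these.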